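A few compounds are considered here, and "the series" means these few. Any claim that something is new, unique, unknown or untested is made for them only; others in the source may bear on it.

Notes on the series. Among the compounds with values here, compound 1 `CC1CC/C(=N\Nc2ccccc2)c2ncc(CC(=O)O)c(=O)n21` is the first point; in a functional assay on the whole organism for inhibition, with Rattus norvegicus as the target (on this read-out higher numbers stand for an effect only at larger amounts of compound and lower numbers for an effect already at smaller amounts), compound 1 gives 100 umol/kg. Compound 2 `CC1CC/C(=N\Nc2ccc(F)cc2)c2ncc(C(=O)O)c(=O)n21` stands lowest of the two numbers; in this assay compound 2 gives 12.2 umol/kg, and the gap to compound 1 lies beyond the scatter. Compound 1 and compound 2 differ in more than one place, so their two values alone carry this comparison.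

Compound 3 `CC1CC/C(=N\Nc2ccc(-c3ccccc3)cc2)c2ncc(C(=O)O)c(=O)n21` is the next member, not yet measured. It differs from compound 2 by phenyl in place of fluoro on an aromatic carbon, the phenyl sitting on an aromatic carbon of a six-membered aromatic ring of carbon only, para to a large group.

Within the data shown here, no measured pair reports a step of this kind, so the expectation rests on compound 2 alone. The step of a 2.0-fold higher number from compound 2 to compound 3 (0.31 log units; beyond the scatter) is expected to be small, toward a somewhat higher number, and may well fall within the scatter. Compound 3 is therefore estimated at 25 umol/kg in this assay, with a range from 8 umol/kg to 80 umol/kg.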

Compound 3, dose for 50% inhibition: 1.1 umol/kg
For compound 3 the middle estimate is 23-fold (1.36 log units) above the measured one; measured number outside the range, below it.
By their numbers in this assay, from the lowest: compound 3; then compound 2; then compound 1.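

Phenyl in place of fluoro on this aromatic carbon, para to a large group, gives an 11-fold lower number from compound 2 to compound 3 (1.04 log units; beyond the scatter) in this assay. Within the data shown here, this is the first change that can be read at a single place, and it shows that this position accepts a group of 6 heavy atoms in place of 1, with the number falling rather than rising. No measurement on hand accounts for the size of this step.

Whether the step depends on the aromatic ring itself or simply on a larger group stays open, since a cyclohexyl, a tert-butyl or a pyridyl on the same carbon lies outside the compounds shown. An amine or a methoxy group at this position, or a second substituent on the added phenyl, is equally untested among these compounds.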